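This account rests on a few compounds, and the source may have more. Where it says the series, first, only, none or still open, it means among the compounds named here.

Of the compounds shown here, two have so far been measured in an assay on a protein complex for inhibition of integrin alpha-5/beta-1 (Homo sapiens), read by ELISA; on this read-out lower numbers stand for stronger inhibition and higher numbers for weaker inhibition. Compound 1 `Cc1cc(C)c(C(=O)N[C@@H](CNC(=O)CO[C@@H]2C[C@@H](CNc3ccccn3)N(C(=O)OCc3ccccc3)C2)C(=O)O)c(C)c1` gives 3.5 nM there. For the measured compounds named here, compound 2 `Cc1cc(C)c(S(=O)(=O)N[C@@H](CNC(=O)CO[C@@H]2C[C@@H](CNc3ccccn3)N(C(=O)CC(C)(C)C)C2)C(=O)O)c(C)c1` gives 6 nM, the higher of the two numbers, yet its only neighbour, compound 1, lies within the usual scatter of it, so the pair cannot be ordered. Compound 3 `Cc1cc(C)c(S(=O)(=O)N[C@@H](CNC(=O)CO[C@@H]2C[C@@H](CNc3ccccn3)N(C(=O)OCc3ccccc3)C2)C(=O)O)c(C)c1` awaits measurement. It differs from compound 2 in one place: benzyloxy in place of neopentyl on a carbonyl carbon. Going by the values given here, no measured step guides this move, so nothing beyond the scatter is expected. The estimated step of a 1.3-fold lower number from compound 2 to compound 3 (0.12 log units; within the scatter) is accordingly small. Compound 3 is expected to give about 4.5 nM in this assay, between 1.5 nM and 14 nM.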

Compound 3, half-maximal inhibitory concentration: 3.7 nM
Compound 3: middle estimate off by 1.2-fold (0.09 log units), on the high side, and the stated range covers the measured number.
By their numbers in this assay, from the lowest: compounds 1, 3 and 2 (each within the scatter of the next).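

In this assay, replacing neopentyl with benzyloxy on the carbonyl carbon gives a 1.6-fold lower number from compound 2 to compound 3 (0.21 log units; within the scatter) and so does not separate these two groups. Replacing (2,4,6-trimethylphenyl)carbonyl with (2,4,6-trimethylphenyl)sulfonyl on the amine nitrogen gives a 1.1-fold higher number from compound 1 to compound 3 (0.02 log units; within the scatter) and likewise separates neither group, so the two places have now each been probed with one change. Nothing measured here offers a cause for these results. Still open, on these data alone, is whether a simple amine or a longer chain on that carbonyl carbon would move the number beyond the scatter.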